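Adding One More Methoxy Group: What to Expect

A few compounds are considered here, and "the series" means these few. Any claim that something is new, unique, unknown or untested is made for them only; others in the source may bear on it.

Of the compounds shown here, three have been measured in a functional assay on MDA-MB-231 cells (Homo sapiens) for inhibition, read by MTT assay, with a stated time of 48 h; on this read-out lower numbers stand for stronger inhibition and higher numbers for weaker inhibition. Compound 1 `COc1ccc(-c2cc(/C=C/C(=O)c3ccc(N)cc3)[nH]n2)cc1` gives 1700 nM, and compound 3 `COc1ccc(-c2cc(/C=C/C(=O)c3ccc(N)cc3)[nH]n2)cc1OC` gives 2200 nM. The step of a 1.3-fold higher number from compound 1 to compound 3 (0.11 log units; within the scatter) comes from methoxy in place of hydrogen on an aromatic carbon. Compound 2 `COc1ccc(C(=O)/C=C/c2cc(-c3cc(OC)c(OC)c(OC)c3)n[nH]2)cc1OC` gives 620 nM in this assay, the lowest number of the three and beyond the scatter from both compound 1 and compound 3; the difference between the core of compound 2 and the core of compound 1 is not broken down here.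

Compound 4 `COc1cc(C(=O)/C=C/c2cc(-c3cc(OC)c(OC)c(OC)c3)n[nH]2)cc(OC)c1OC` has not yet been measured. It differs from compound 2 by methoxy in place of hydrogen on an aromatic carbon, the same kind of change as from compound 1 to compound 3, though here the place is also meta to a methoxy group. Because the step of a 1.3-fold higher number from compound 1 to compound 3 (0.11 log units; within the scatter) stayed within the scatter, only a small step is expected here as well. The expected step is a 1.3-fold higher number from compound 2 to compound 4 (0.11 log units; within the scatter). The estimate for compound 4 in this assay is 800 nM, expected to fall between 300 nM and 2000 nM.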

Compound 4, half-maximal inhibitory concentration: 700 nM
Estimate against measurement, compound 4: 1.1-fold (0.06 log units) above; measured number inside the range.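

In this assay, methoxy in place of hydrogen on an aromatic carbon gives a small step on this second core, a 1.1-fold higher number from compound 2 to compound 4 (0.05 log units; within the scatter). Set beside the earlier step, the change behaves alike on the two cores: the same change on two cores in this assay, a 1.3-fold higher number (0.11 log units; within the scatter) from compound 1 to compound 3 and a 1.1-fold higher number (0.05 log units; within the scatter) from compound 2 to compound 4, 1.1-fold (0.06 log units) apart, within the scatter of two such steps. This shows that the step carried over between these two cores in this one assay, but it does not show that it would carry over to other cores, and it does not explain why the two steps agree.

The compounds shown leave open what a different group, such as a hydroxyl, an ethoxy or a chlorine, would do in place of that hydrogen. They also leave open whether such a group would give a step beyond the scatter on either core.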